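A few compounds are considered here, and "the series" means these few. Any claim that something is new, unique, unknown or untested is made for them only; others in the source may bear on it.

Compound 1, `O=C(/C=C/c1cccc(F)c1)Nc1ccc(CC2=CC(=O)OC2)cc1`, and compound 2, `C=C1OC(=O)C=C1Cc1ccc(NC(=O)/C=C/c2ccccc2)cc1`, share an amide-linked cinnamoyl arm on a benzylated lactone core, but they differ from each other in two places at once, so their two values can only be set side by side. In an assay on isolated protein for inhibition of DNA topoisomerase 1 (Homo sapiens), with a stated time of 30 min, tested at 100 uM (a lower number here means less inhibition, a higher number more inhibition at the concentration tested (going by the name of the read-out)), compound 1 gives 13.1%, while compound 2 gives 48.6%, the higher of the two numbers by a gap that lies beyond the usual scatter.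

Compound 3, `C=C1OC(=O)C=C1Cc1ccc(NC(=O)/C=C/c2cccc(F)c2)cc1`, is built from compound 2 by a single change: fluoro in place of hydrogen on an aromatic carbon. The fluorine sits on an aromatic carbon of a six-membered aromatic ring of carbon only, meta to a large group, and nothing else in the molecule moves.

Among the compounds with values here, no measured pair shows this exact change on this core, so the size of its effect is open. Compound 1 carries the same fluoro group on a different core and gives 13.1%, a lower number, but that comparison mixes two changes. The step from compound 2 to compound 3 is expected to be small, a number 8.6 percentage points lower from compound 2 to compound 3 (within the scatter), leaning downward but plausibly within the scatter. Compound 3 is therefore estimated to give 40% in this assay, with a likely range from 20% to 60%.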

Compound 3, a percentage reported as inhibition, at one concentration (the size of the read-out at that concentration, not a potency): 34.5%
Estimate against measurement, compound 3: 5.5 percentage points above; the measured number falls inside the stated range.
By their numbers in this assay, from the lowest: compound 1; then compound 3; then compound 2.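

In this assay, going from phenyl to 3-fluorophenyl, with fluoro on an aromatic carbon meta to a large group, gives a number 14.1 percentage points lower from compound 2 to compound 3 (beyond the scatter), so this position responds to the change even though only a single hydrogen is replaced. Within the data shown here, compound 3 also allows the first clean reading at the other end of the molecule: with the 3-fluorophenyl group held fixed, a group of 7 heavy atoms in place of a group of 6 heavy atoms, both with a five-membered non-aromatic ring, gives a number 21.4 percentage points higher from compound 1 to compound 3 (beyond the scatter). Compound 3 therefore connects compound 1 and compound 2 through two single changes, and each step lies beyond the scatter.

On these data alone, whether a chloro or a methoxy group at this same place would behave like fluoro remains open, as does whether the fluoro step would carry over to the core of compound 1. Nothing available here explains why either step goes in its direction.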